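Trimming a Methyl from the Hydroxypiperidine Amide

A few compounds are considered here, and "the series" means these few. Any claim that something is new, unique, unknown or untested is made for them only; others in the source may bear on it.

Compound 3 `COc1cc(C(=O)N2CC[C@@H](O)C(C)(C)C2)cc2nc(NCc3cccc(Cl)c3)oc12` gives 35 nM in an assay on isolated protein for inhibition of thyroid hormone receptor beta (Homo sapiens), read by fluorescence, with a stated time of 30 min; on this read-out higher numbers stand for weaker inhibition and lower numbers for stronger inhibition. Among the three measured compounds it sits second highest: compound 2 `COc1cc(C(=O)N2CCCC2(C)C)cc2nc(NCc3cccc(Cl)c3)oc12` gives 47 nM, and the pair lie within the scatter of each other (a 1.3-fold lower number from compound 2 to compound 3 (0.13 log units; within the scatter)), while compound 1 `CCCN(CC1CCOC1)C(=O)c1cc(OC)c2oc(NCc3cccc(Cl)c3)nc2c1` gives 12 nM, separated by a clear step (a 2.9-fold higher number from compound 1 to compound 3 (0.46 log units; beyond the scatter)). Compound 4 `COc1cc(C(=O)N2CCC(O)C(C)C2)cc2nc(NCc3cccc(Cl)c3)oc12` carries 4-hydroxy-3-methylpiperidin-1-yl in place of 4-hydroxy-3,3-dimethylpiperidin-1-yl on a carbonyl carbon. Within the data shown here, no measured step removes a single methyl from an amide substituent; the steps that touch this position replace the whole group, and the only swap between two cyclic amides stayed within the scatter. A small change in this assay, not beyond the scatter, is therefore expected for compound 4, which is estimated at 45 nM (range 18 nM to 110 nM), a step of a 1.3-fold higher number from compound 3 to compound 4 (0.11 log units; within the scatter) expected from compound 3.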

Compound 4, half-maximal inhibitory concentration: 25 nM
The estimate for compound 4 lay 1.8-fold (0.26 log units) above the measured number, within the range that was stated.
By their numbers in this assay, from the lowest: compound 1; then compounds 4, 3 and 2 (each within the scatter of the next).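

Trimming one methyl from the 4-hydroxy-3,3-dimethylpiperidin-1-yl group keeps the result in this assay within the scatter (a 1.4-fold lower number from compound 3 to compound 4 (0.15 log units; within the scatter)), the first measured step that alters this amide substituent without replacing it whole. Compound 4 also lies within the scatter of the 2,2-dimethylpyrrolidin-1-yl amide (a 1.9-fold lower number from compound 2 to compound 4 (0.27 log units; within the scatter)), while the ((oxolan-3-yl)methyl)(propyl)amino amide remains separated from it (a 2.1-fold higher number from compound 1 to compound 4 (0.32 log units; beyond the scatter)). No available evidence bears on this result.

Open, going by these compounds, is whether 4-hydroxypiperidin-1-yl with no methyl, or with an ethyl instead, would stay within this scatter. Also open, on these data alone, is how the individual stereoisomers of compound 4 compare.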